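The source may hold more compounds than are shown below. What is called first, only, known or untested is meant among the compounds shown, and "the series" means these compounds.

Going by the values given here, in an ADME assay on L6 cells (Rattus norvegicus) for cytotoxicity, read by resazurin assay, with a stated time of 72 h (on this read-out lower numbers stand for stronger inhibition and higher numbers for weaker inhibition), compound 2 `CCOc1ccc(C(=O)NC(=O)c2ccccc2O)cc1` gives 17 ug/mL, the lowest of the two numbers so far, while compound 1 `O=C(NC(=O)c1ccccc1O)c1ccc([N+](=O)[O-])cc1` gives 53 ug/mL. Compound 3 `Nc1ccc(C(=O)NC(=O)c2ccccc2O)cc1` differs from compound 2 in one place: amino in place of ethoxy on an aromatic carbon. Among the compounds with values here, the only measured step at this place is a 3.1-fold lower number from compound 1 to compound 2 (0.49 log units; beyond the scatter), with ethoxy in place of nitro, a modest change. One step is thin evidence, but a similarly modest move toward a higher number is expected, and the estimated step is a 1.9-fold higher number from compound 2 to compound 3 (0.29 log units; within the scatter). For compound 3 the expected value is 33 ug/mL, with a range of 12 ug/mL to 90 ug/mL.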

Compound 3, half-maximal inhibitory concentration: 39 ug/mL
For compound 3 the middle estimate is 1.2-fold (0.07 log units) below the measured one, and the stated range covers the measured number.
By their numbers in this assay, from the lowest: compound 2; then compounds 3 and 1 (each within the scatter of the next).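

At this position, the number in this assay depends on the group: the change from ethoxy to amino gives a 2.3-fold higher number from compound 2 to compound 3 (0.36 log units; beyond the scatter), so the lower number of compound 2 does not carry over to amino. Amino and nitro cannot be told apart here, with a 1.4-fold lower number from compound 1 to compound 3 (0.13 log units; within the scatter). Ethoxy alone stands apart among these three groups, and no measurement here explains this. Still open, as far as these compounds go, is whether the oxygen or the carbon chain of ethoxy matters; a methoxy, propoxy or plain ethyl group would help separate the two.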